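The compounds below may be only part of what the source reports. "The series", "measured", "known", "first", "only" and "open" are said of these compounds alone.

Of the compounds shown here, two have so far been measured in an assay on CHO cells for displacement of a labelled ligand from histamine receptor H3 (Macaca mulatta), read by scintillation counting, with a stated time of 1 h; on this read-out lower numbers stand for stronger inhibition and higher numbers for weaker inhibition. Compound 1 `Cc1cc(NC(=O)NC2CCCCC2)ccc1N1CCC(N2CCCC2C)C1` gives 11.2 nM in this assay, and compound 2 `CC(=O)N(C)C1CCN(C(=O)Nc2ccc(N3CCC(N4CCCC4C)C3)cc2)C1` gives 35.5 nM. Compound 2 thus stands at the higher of the two numbers, and its gap to compound 1 lies beyond the scatter; the two differ in more than one place, so this gap cannot be assigned to a single change. Compound 3 `CC(=O)N(C)C1CCN(C(=O)Nc2ccc(N3CCC(N4CCCC4C)C3)c(C)c2)C1` is derived from compound 2 by methyl in place of hydrogen on an aromatic carbon. Within the data shown here, no measured pair isolates this change. Since compound 1 gives 11.2 nM with the methyl present, a modest move toward lower numbers is expected for this step a 1.6-fold lower number from compound 2 to compound 3 (0.21 log units; within the scatter), although an outcome within the scatter would not be surprising. Compound 3 is therefore expected to give about 22 nM in this assay, with a range from 8 nM to 60 nM.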

Compound 3, inhibition constant: 89.7 nM
The estimate for compound 3 lay 4.1-fold (0.61 log units) below the measured number, and the stated range ends below it.
By their numbers in this assay, from the lowest: compound 1; then compound 2; then compound 3.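

Methyl in place of hydrogen on this aromatic carbon, ortho to a large group and meta to a large group, gives a 2.5-fold higher number from compound 2 to compound 3 (0.40 log units; beyond the scatter) in this assay and so moves the number toward weaker inhibition, a direction that no earlier pair could isolate. With the methyl kept, 3-(acetyl(methyl)amino)pyrrolidin-1-yl in place of cyclohexylamino on a carbonyl carbon gives an 8.0-fold higher number from compound 1 to compound 3 (0.90 log units; beyond the scatter) in this assay and also moves toward weaker inhibition, so both single changes point the same way here. No measurement shown accounts for either step.

The compounds shown leave open whether the methyl step would keep its direction and size with cyclohexylamino on the carbonyl carbon. They also leave open how a fluorine, a chlorine or an ethyl group on this same aromatic carbon would compare with methyl.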